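A phenethyl chain on a compound at the limit

This account rests on a few compounds, and the source may have more. Where it says the series, first, only, none or still open, it means among the compounds named here.

Compound 1 `C#CCCCCOc1ncc(-c2ccccc2OC)n1C`: 21000 nM
Compound 2 `COc1ccccc1-c1cnc(OC)n1C`: > 100000 nM
Compound 3 `C=CCCCCOc1ccccc1-c1cnc(OC)n1C`: 86000 nM

In a functional assay on PC-3 cells (Homo sapiens) for inhibition, read by colorimetric assay and MTT assay, with a stated time of 72 h (on this read-out higher numbers stand for weaker inhibition and lower numbers for stronger inhibition), compound 2 reads > 100000 nM, which is a limit and not a number. Compound 4 `COc1ccccc1-c1cnc(OCCCc2ccccc2)n1C` carries phenethyl in place of hydrogen on a saturated chain carbon bound to an oxygen on an aromatic ring. Two measured steps at that place bear on it. Losing pent-4-yn-1-yl gave an at least 4.7-fold higher number from compound 1 to compound 2 (0.67 log units; beyond the scatter), beyond the scatter, while gaining pent-4-en-1-yl gave an at least 1.1-fold lower number from compound 2 to compound 3 (0.06 log units; that floor lies within the scatter), whose floor lies within the scatter. A move toward stronger inhibition is therefore expected in this assay, of uncertain size. The expected step is an at least 2.2-fold lower number from compound 2 to compound 4 (0.34 log units; beyond the scatter). For compound 4 the estimated value is 45000 nM, with an expected range of 15000 nM to 100000 nM.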

Compound 4, half-maximal inhibitory concentration: 27000 nM
Compound 4: the middle estimate sits 1.7-fold (0.22 log units) above what was measured; the measured number falls inside the stated range.
By their numbers in this assay, from the lowest: compounds 1 and 4 (each within the scatter of the next); then compound 3. At a limit, above all of these: compound 2.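

In this assay, phenethyl at this place, on a saturated chain carbon bound to an oxygen on an aromatic ring, gives an at least 3.7-fold lower number from compound 2 to compound 4 (0.56 log units; beyond the scatter), so a chain ending in an aromatic ring also serves here. With phenyl in place of propargyl, the chain end gives a 1.3-fold higher number from compound 1 to compound 4 (0.11 log units; within the scatter), so propargyl is not needed to reach this level. That first step is only a floor because compound 2 stands at a limit: the limit of > 100000 nM in this assay, at which 1 of the 4 values shown sits.

On these data alone, whether an amine or a carboxylic acid at the chain end would keep this level stays open. So does the effect of a longer chain.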